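A few compounds are considered here, and "the series" means these few. Any claim that something is new, unique, unknown or untested is made for them only; others in the source may bear on it.

Of the compounds shown here, three have been measured in an ADME assay on MT4 cells (Homo sapiens) for cytotoxicity, read by MTT assay; a lower number here means that less compound is tolerated, a higher number that more compound is tolerated. Compound 1 `Cc1ccc(NC(=O)CSc2nncnc2-c2cccc3ccccc23)c(Br)c1` gives 166000 nM, and compound 3 `Cc1ccc(NC(=O)CSc2nncnc2-c2cccc3ccccc23)c([N+](=O)[O-])c1`, which differs from it only by nitro in place of bromo on an aromatic carbon, gives 147000 nM; the step of a 1.1-fold lower number from compound 1 to compound 3 (0.05 log units; within the scatter) lies within the scatter. Compound 2 `O=C(CSc1nncnc1-c1ccccc1Cl)c1ccc(Cl)c(Cl)c1` gives 33000 nM, the lowest of the three numbers and beyond the scatter from both others, so the cells tolerate less of compound 2 than of the other two.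

Compound 4 `O=C(CSc1nncnc1-c1ccccc1Cl)Nc1ccccc1Cl` differs from compound 2 in one place: (2-chlorophenyl)amino in place of 3,4-dichlorophenyl on a carbonyl carbon. Going by the values given here, no measured pair shows this change, and the single measured step concerns a different part of the molecule and lies within the scatter, so it offers no guide here. What the numbers do show is that compound 1 and compound 3, in which, as in compound 4, an amino group sits on the carbonyl carbon, stand well above compound 2 in this assay. On that basis an upward step is expected, a 2.7-fold higher number from compound 2 to compound 4 (0.44 log units; beyond the scatter). The estimate for compound 4 is 90000 nM, with a likely range from 30000 nM to 250000 nM.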

Compound 4, half-maximal cytotoxic concentration: 90000 nM
Estimate against measurement, compound 4: no gap at the digits printed; measured number inside the range.
By their numbers in this assay, from the lowest: compound 2; then compounds 4, 3 and 1 (each within the scatter of the next).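

Going by these compounds alone, replacing 3,4-dichlorophenyl with (2-chlorophenyl)amino on the carbonyl carbon gives a 2.7-fold higher number from compound 2 to compound 4 (0.44 log units; beyond the scatter) in this assay, the first reading for a change at this position and one that lies beyond the usual scatter. Within the data shown here, the earlier single-place step, a 1.1-fold lower number from compound 1 to compound 3 (0.05 log units; within the scatter), lay within the scatter and concerned another part of the molecule, so this result is the first sign that a single change can shift how much compound the cells tolerate. The swap alters two things at once, bringing in a nitrogen with its hydrogen-bond donor and changing the chlorines on the ring, and no measurement here explains the step.

The compounds shown leave open whether the nitrogen or the chlorine pattern carries the step. A plain phenylamino group on the carbonyl carbon would help separate the two, while a morpholine ring there would test a non-aromatic amine.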